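Swapping 3-methoxyphenyl for furan-2-yl in compound 1

The source may report more compounds than this note shows. Statements on the series, on what has been measured and on what is new or still open speak of the compounds shown alone.

Measured in a functional assay on COLO 205 cells (Homo sapiens) for inhibition, read by sulforhodamine B assay, with a stated time of 48 h, tested at 50 uM; a higher number here means more inhibition of growth at the concentration tested, a lower number less inhibition of growth:
compound 1 `COc1cccc(/C=C/C(=O)/C=C/c2ccc(OCc3cn(CCOc4cc(=O)oc5ccccc45)nn3)c(OC)c2)c1` gives 69%
compound 2 `COc1cc(/C=C/C(=O)/C=C/c2cccs2)ccc1OCc1cn(CCCCCOc2cc(=O)oc3ccccc23)nn1` gives 30%
compound 3 `COc1ccccc1/C=C/C(=O)/C=C/c1ccc(OCc2cn(CCCCCOc3cc(=O)oc4ccccc34)nn2)c(OC)c1` gives 30%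

Compound 1 stands highest of the three, and its gaps down to compound 2 and to compound 3 both lie beyond the scatter. Compound 4 `COc1cc(/C=C/C(=O)/C=C/c2ccco2)ccc1OCc1cn(CCOc2cc(=O)oc3ccccc23)nn1` keeps the core of compound 1 but carries furan-2-yl in place of 3-methoxyphenyl, on a double-bonded chain carbon bound to a double-bonded chain carbon: furan-2-yl in place of 3-methoxyphenyl on a double-bonded chain carbon bound to a double-bonded chain carbon. Going by the values given here, one measured step bears on this place, no change at the digits printed from compound 2 to compound 3 (within the scatter), which exchanges thiophen-2-yl for 2-methoxyphenyl there. It is only a thin guide, since both of its compounds sit far lower than compound 1 and furan-2-yl itself has not been measured. Even so, it gives no reason to expect a large shift in this assay from this exchange. The estimate is a number 7 percentage points lower from compound 1 to compound 4 (within the scatter), a small expected fall that stays within the scatter. Compound 4 is expected at 62%, with an estimated range from 42% to 80% in this test.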

Compound 4, percent growth inhibition at one concentration: 68%
For compound 4 the middle estimate is 6 percentage points below the measured one; measured number inside the range.
By their numbers in this assay, from the lowest: compounds 2 and 3 (each within the scatter of the next); then compounds 4 and 1 (each within the scatter of the next).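

In this assay, the exchange at this place, on a double-bonded chain carbon bound to a double-bonded chain carbon, gives a number 1 percentage points lower from compound 1 to compound 4 (within the scatter). Going by these compounds alone, the earlier step there, no change at the digits printed from compound 2 to compound 3 (within the scatter), came from a different pair, so this is the first reading of a change at this place on the core of compound 1. It shows that going from a six-membered aromatic ring of carbon only, with 8 heavy atoms, to a five-membered aromatic ring with 1 hetero atom, with 5 heavy atoms, leaves the read-out within the scatter there, and no measurement at hand offers an explanation for this. As far as these compounds go, how a ring carrying an amine or a carboxylic acid would read at this place remains open. Also open, from the compounds shown here alone, is whether furan-2-yl would give the same result on the compounds with the longer chain.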